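The source may hold more compounds than are shown below. What is called first, only, known or untested is meant among the compounds shown, and "the series" means these compounds.

Of the compounds shown here, three have so far been tested in a functional assay on KYSE-450 cells (Homo sapiens) for inhibition, read by MTT assay, with a stated time of 48 h; on this read-out lower numbers stand for stronger inhibition and higher numbers for weaker inhibition. Compound 1 `COc1cc(NCc2ccccc2)cc(OC)c1OC` does not give a number in this assay: compound 1 gives > 80000 nM, which is a limit of the assay, (the limit of > 80000 nM in this assay, at which 1 of the 3 values shown sits). Compound 2 `COc1cc(NCc2cccc(O)c2)cc(OC)c1OC` carries a hydroxy group on the benzyl ring, and in this assay compound 2 gives 71300 nM. Going from compound 2 to compound 1, the change is hydrogen in place of hydroxy on an aromatic carbon, and this brings an at least 1.1-fold higher number from compound 2 to compound 1 (0.05 log units; that floor lies within the scatter). Compound 3 `C/C=C/C(=O)N(Cc1ccc(OC)c(O)c1)c1cc(OC)c(OC)c(OC)c1` is built on a different core; the difference between the core of compound 3 and the core of compound 2 is not broken down here. In this assay compound 3 gives 67 nM, the lowest of the two numbers measured.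

Compound 4 `C/C=C/C(=O)N(Cc1ccc(OC)cc1)c1cc(OC)c(OC)c(OC)c1` has not yet been measured. It differs from compound 3 by hydrogen in place of hydroxy on an aromatic carbon. Going by the values given here, this is the same kind of change as the one from compound 2 to compound 1, but not the same: in compound 3 the hydroxy that leaves sits ortho to a methoxy group and meta to a large group, whereas in compound 2 it sits only meta to a large group. Among the compounds with values here, the one measured instance of this kind of change, an at least 1.1-fold higher number from compound 2 to compound 1 (0.05 log units; that floor lies within the scatter), is small and offers little guidance on its own, so the expectation for compound 4 stays close to compound 3 with a modest weakening. Compound 4 is expected to give about 200 nM in this assay, most likely between 60 nM and 800 nM. For compound 4 this estimate means a step of a 3.0-fold higher number from compound 3 to compound 4 (0.47 log units; beyond the scatter).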

Compound 4, half-maximal inhibitory concentration: 420 nM
Compound 4: the middle estimate sits 2.1-fold (0.32 log units) below what was measured, and the stated range covers the measured number.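

In this assay, replacing the hydroxy with hydrogen, which turns the 3-hydroxy-4-methoxyphenyl group into 4-methoxyphenyl, gives a 6.3-fold higher number from compound 3 to compound 4 (0.80 log units; beyond the scatter), so on this core the hydroxy clearly matters for the read-out. This does not show that the change has the same size on every core, nor that its size depends on the core: the same change on two cores in this assay, an at least 1.1-fold higher number (0.05 log units; that floor lies within the scatter) from compound 2 to compound 1 and a 6.3-fold higher number (0.80 log units; beyond the scatter) from compound 3 to compound 4; the limit leaves it open whether they differ. On the core of compound 1 the step rests on a limit and not on a number, so that step gives only a floor, and the shown compounds cannot say how far it really reaches: the limit of > 80000 nM in this assay, at which 1 of the 4 values shown sits.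

The compounds shown leave open whether another group on that aromatic carbon, such as an amine or a fluorine atom, would give a number closer to that of compound 3 or closer to that of compound 4, and so whether the hydroxy itself is needed there. They also leave open how a longer chain on the amide carbonyl would change the number, and how much of the wide gap between the core of compound 2 and the core of compound 3 each single structural difference accounts for.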